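Swapping a fluorophenylpropyl chain for a methylthiophene ethoxy

The compounds below may be only part of what the source reports. "The series", "measured", "known", "first", "only" and "open" are said of these compounds alone.

Of the compounds shown here, three sharing one core have been measured in an ADME assay on microsomes from liver (Rattus norvegicus) for metabolic stability, read by LC-MS, tested at 0.5 uM; on this read-out lower numbers stand for a shorter-lived compound and higher numbers for a longer-lived compound. Compound 1 `Cc1nc(C)c([C@H](OC(C)(C)C)C(=O)O)c(N2CCC(C)(C)CC2)c1-c1ccc(OCCc2ccc(F)c(F)c2)cc1` gives 0.85 h in this assay. Compound 2 `Cc1nc(C)c([C@H](OC(C)(C)C)C(=O)O)c(N2CCC(C)(C)CC2)c1-c1ccc(OCCc2cc(F)c(F)cc2F)cc1` carries one more fluorine than compound 1. In this assay compound 2 reaches a limit of the assay, > 2 h. Compound 3 `Cc1nc(C)c([C@H](OC(C)(C)C)C(=O)O)c(N2CCC(C)(C)CC2)c1-c1ccc(CCCc2ccc(F)cc2)cc1` likewise reaches a limit of the assay, > 2 h. Two of the three values sit at that limit (the limit of > 2 h in this assay, at which 2 of the 3 values shown sit), so compound 3 stands at the upper end of the numbers shown, and the step of an at least 2.3-fold higher number from compound 1 to compound 3 (0.37 log units; beyond the scatter) places it clearly beyond compound 1. The step that the two limits leave unreadable from compound 2 to compound 3 cannot be sized.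

Compound 4 `Cc1ccc(CCOc2ccc(-c3c(C)nc(C)c([C@H](OC(C)(C)C)C(=O)O)c3N3CCC(C)(C)CC3)cc2)s1` differs from compound 3 in one place: 2-(5-methylthiophen-2-yl)ethoxy in place of 3-(4-fluorophenyl)propyl on an aromatic carbon. This change brings back the ethoxy connection that compound 1 carries, while the six-membered aromatic ring of carbon only gives way to a five-membered aromatic ring with one hetero atom. Among the measured compounds shown here, the measured step that bears on it is an at least 2.3-fold higher number from compound 1 to compound 3 (0.37 log units; beyond the scatter), which ran in the opposite direction; reversing the linker is therefore expected to shorten the half-life by a modest step, an at least 2.0-fold lower number from compound 3 to compound 4 (0.30 log units; that floor lies within the scatter), although the methylthiophene itself has no measured counterpart here. For compound 4 the estimated value in this assay is 1 h, with a range from 0.4 h to 2.5 h.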

Compound 4, half-life: > 2 h
Compound 4 was reported as a limit; the forecaster's own chance of this, stated with the estimate: 25%; middle value at least 2.0-fold (0.30 log units) away from the limit.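

In this assay compound 4 also reaches a limit of the assay, > 2 h. With the ethoxy connection kept, 5-methylthiophen-2-yl in place of 3,4-difluorophenyl gives an at least 2.3-fold higher number from compound 1 to compound 4 (0.37 log units; beyond the scatter), so this position does not need a fluorine-bearing six-membered ring for the half-life to reach the limit: compound 2 and compound 3 both carry fluorine, while compound 4 carries none and has a five-membered aromatic ring with one hetero atom instead. The steps to compound 4 from compound 2 and from compound 3 cannot be read, so the order among these three stays unknown, and the top of the range offers no room to separate them: the limit of > 2 h in this assay, at which 3 of the 4 values shown sit.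

On these data alone, how far compound 2, compound 3 and compound 4 each lie beyond the limit remains open, and so does any ranking of their end groups. Also open, as far as these compounds go, is what the methyl on the thiophene contributes, which a plain thiophen-2-yl group would test, and whether 3-(5-methylthiophen-2-yl)propyl, joining the same ring to the all-carbon chain of compound 3, would behave like compound 4.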